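The source may report more compounds than this note shows. Statements on the series, on what has been measured and on what is new or still open speak of the compounds shown alone.

Measured compounds in an assay on HEK293 cells for inhibition of Toll-like receptor 8 (Homo sapiens), with a stated time of 16 h; on this read-out higher numbers stand for weaker inhibition and lower numbers for stronger inhibition:

- compound 3 `O=C(Nc1ccc(Oc2cccc(C(F)(F)F)c2)cc1)c1c(F)cccc1Cl` gives 2410 nM
- compound 2 `Nc1ccc(C(=O)Nc2ccc(Oc3cc(C(F)(F)F)cc(C(F)(F)F)c3)cc2)c(F)c1` gives > 50000 nM
- compound 1 `O=C(Nc1ccc(Oc2cc(C(F)(F)F)cc(C(F)(F)F)c2)cc1)c1c(F)cccc1C(F)(F)F` gives "not determined" (no result reported)

Compound 3 stands as the only single number shown in this assay. Of the other two entries, one is a limit and one carries no result at all. The value for compound 2 is a limit of the assay, not a number, and it sits at the limit of > 50000 nM in this assay, at which 1 of the 3 values shown sits. Compound 1 has no result reported, so nothing can be said of how it compares with compound 3.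

Compound 4 `O=C(Nc1ccc(Oc2cc(Cl)cc(C(F)(F)F)c2)cc1)c1c(F)cccc1Cl` differs from compound 3 in a single place: chloro in place of hydrogen on an aromatic carbon, the new chloro sitting meta to a trifluoromethyl group on the six-membered aromatic ring of carbon only that carries the ether oxygen.

For the measured compounds named here, no step between measured compounds is available to calibrate this change. The expectation is a modest step toward stronger inhibition in this assay, of a size that may still fall within the usual scatter, with no grounds for a shift toward the limit. For compound 4 the estimate is 1200 nM, within a range from 300 nM to 5000 nM, meaning an expected step of a 2.0-fold lower number from compound 3 to compound 4 (0.30 log units; within the scatter).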

Compound 4, half-maximal inhibitory concentration: 2040 nM
For compound 4 the middle estimate is 1.7-fold (0.23 log units) below the measured one; measured number inside the range.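

Chloro in place of hydrogen on an aromatic carbon, meta to a trifluoromethyl group, gives in this assay a 1.2-fold lower number from compound 3 to compound 4 (0.07 log units; within the scatter). For the compounds shown here, this is the first comparison between measured compounds that differ in one place, and it shows that adding chloro at this position leaves the read-out within the scatter, so the reading for this pair cannot be separated. Nothing in the data shown bears on why this step is so small.

Going by these compounds, whether a larger change on the same carbon, such as a methoxy group or a nitrile, would move the number beyond the scatter remains open. A single step also leaves open whether chloro would behave the same way on a core with a different group on the other aromatic ring.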